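This account rests on a few compounds, and the source may have more. Where it says the series, first, only, none or still open, it means among the compounds named here.

Measured compounds:
compound 1 `COc1ccccc1/C=c1/[nH]c(=O)/c(=C\c2ccccc2OC)n(C)c1=O`: 1500 nM
compound 2 `COc1ccccc1/C=c1/[nH]c(=O)/c(=C\c2cccc(Cl)c2Cl)[nH]c1=O`: "not active" (no number reported)
compound 3 `C=CCn1c(=O)/c(=C\c2ccccc2OC)[nH]c(=O)/c1=C\c1ccccc1OC`: 5100 nM

In a functional assay on U-937 cells (Homo sapiens) for cytotoxicity, read by CCK-8 assay, with a stated time of 72 h (on this read-out higher numbers stand for weaker inhibition and lower numbers for stronger inhibition), compound 3 gives the highest number of the two entries that carry one; its nearest neighbour is compound 1, which is separated from it by a 3.4-fold higher number from compound 1 to compound 3 (0.53 log units; beyond the scatter). Compound 2 returned no number in this assay and is reported only as inactive, so it offers no scale for comparison.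

Compound 4 `COc1ccccc1/C=c1/[nH]c(=O)/c(=C\c2ccccc2OC)[nH]c1=O` differs from compound 3 by hydrogen in place of allyl on an aromatic nitrogen. For the measured compounds named here, only one measured step touches the same site: the change from compound 1 to compound 3, where adding vinyl to the chain on the aromatic nitrogen gave a modestly higher number, beyond the scatter. Taking away the whole allyl and leaving hydrogen is a change in the opposite sense, and there is no measured pair that reproduces it exactly. Going by the values given here, the single relevant step suggests a smaller group on that nitrogen goes with a lower number, so compound 4 is expected to move back toward the value of compound 1, by a step of about a 2.3-fold lower number from compound 3 to compound 4 (0.37 log units; beyond the scatter), though with wide uncertainty. Compound 4 is therefore estimated at 2200 nM, within a range from 700 nM to 8000 nM.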

Compound 4, half-maximal inhibitory concentration: "not active" (no number reported)
Compound 4 has no reported number here; no gap can be computed for the estimate.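

In this assay, for the compounds shown here, compound 4 is reported only as not active, with no number, so no step from compound 3 to compound 4 can be read. The compounds shown leave open how the group on the aromatic nitrogen relates to the read-out once that nitrogen carries hydrogen. No evidence here bears on this result.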